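Chlorophenyl to Difluorophenyl: An Expected Step in Binding

The source may hold more compounds than are shown below. What is called first, only, known or untested is meant among the compounds shown, and "the series" means these compounds.

Of the compounds shown here, three have been measured in an assay on HEK293 cells for displacement of a labelled ligand from Melanocortin receptor 4 (Homo sapiens); a lower number here means a stronger inhibitor, a higher number a weaker inhibitor. Compound 1 `CC(=O)N1C[C@@H](C(=O)N2CCN(c3ccc(C)cc3[C@@H](NC(=O)CCN(C)C)C(C)C)CC2)[C@H](c2ccc(Cl)cc2)C1` gives 7.6 nM, compound 3 `Cc1ccc(N2CCN(C(=O)[C@@H]3CNC[C@H]3c3ccc(Cl)cc3)CC2)c([C@@H](NC(=O)CCN(C)C)C(C)C)c1` gives 7.2 nM, and compound 2 `CC(C)[C@H](NC(=O)CCN(C)C)c1cccc(F)c1N1CCN(C(=O)[C@@H]2CN(C(C)C)C[C@H]2c2ccc(Cl)cc2)CC1` gives 5.3 nM, the lowest of the three numbers, though its gaps to compound 3 and to compound 1 both lie within the scatter. Among the measured compounds shown here, the one single-point step known so far, a 1.1-fold lower number from compound 1 to compound 3 (0.02 log units; within the scatter), concerns a different part of the shared core and does not bear on the present change. Compound 4 `CC(C)[C@H](NC(=O)CCN(C)C)c1cccc(F)c1N1CCN(C(=O)[C@@H]2CN(C(C)C)C[C@H]2c2cc(F)cc(F)c2)CC1` differs from compound 2 by 3,5-difluorophenyl in place of 4-chlorophenyl on a saturated ring carbon. For the measured compounds named here, no measured step tests this exchange, so the expectation rests on compound 2 alone and carries a wide range. Compound 4 is estimated at 12 nM, between 4 nM and 40 nM, which means an expected step of a 2.3-fold higher number from compound 2 to compound 4 (0.35 log units; beyond the scatter).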

Compound 4, inhibition constant: 7800 nM
Compound 4: middle estimate off by 650-fold (2.81 log units), on the low side; the measured number lies above the stated range.
By their numbers in this assay, from the lowest: compounds 2, 3 and 1 (each within the scatter of the next); then compound 4.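

Exchanging 4-chlorophenyl for 3,5-difluorophenyl on the saturated ring carbon gives a 1500-fold higher number from compound 2 to compound 4 (3.17 log units; beyond the scatter) in this assay. This position is therefore highly sensitive to the group it carries, unlike the ring amine nitrogen, where the earlier change gave a 1.1-fold lower number from compound 1 to compound 3 (0.02 log units; within the scatter). No measurement shown here explains the size of this loss.

On these data alone, it remains open whether the loss comes from removing the 4-chloro substituent or from adding the two fluorines. A plain phenyl or a 4-fluorophenyl group on this carbon would help separate these two possibilities.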